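The compounds below may be only part of what the source reports. "The series", "measured", "known", "first", "only" and "open" are said of these compounds alone.

Compound 1 `O=C(Nc1ccc(NCC2CCCC2)cc1Cl)c1cc(Cl)ccc1O`: 21500 nM
Compound 2 `O=C(Nc1ccc(NC2CCCCC2)cc1Cl)c1cc(Cl)ccc1O`: 68300 nM
Compound 3 `CN(C)c1ccc(CNc2ccc(NC(=O)c3cc(Cl)ccc3O)c(Cl)c2)cc1`: 24500 nM

These three values come from an ADME assay on A549 cells (Homo sapiens) for cytotoxicity, read by resazurin assay, with a stated time of 48 h; on this read-out lower numbers stand for higher toxicity in this test and higher numbers for lower toxicity in this test. Compound 3, at 24500 nM, lies within the scatter of compound 1, while compound 2 stands clear of both with the highest number. The next analogue, compound 4 `O=C(Nc1ccc(NCc2cccnc2Cl)cc1Cl)c1cc(Cl)ccc1O`, replaces the aryl group of compound 3: 2-chloropyridin-3-yl in place of 4-(dimethylamino)phenyl on a saturated chain carbon bound to a nitrogen on an aromatic ring, (2-chloropyridin-3-yl in place of 4-(dimethylamino)phenyl on a saturated chain carbon bound to a nitrogen on an aromatic ring). Among the measured compounds shown here, no measured compound carries the incoming group, so the evidence is indirect. For the measured compounds named here, the closest precedent is an exchange on that same carbon, 4-(dimethylamino)phenyl in place of cyclopentyl, which gave a 1.1-fold higher number from compound 1 to compound 3 (0.06 log units; within the scatter). Going by the values given here, the only step beyond the scatter, a 3.2-fold higher number from compound 1 to compound 2 (0.50 log units; beyond the scatter), was modest and involved a cyclohexyl group on the nitrogen. No step beyond the scatter is therefore expected in this assay, in either direction. The expected step is a 1.1-fold higher number from compound 3 to compound 4 (0.03 log units; within the scatter). For compound 4 the estimated value is 26000 nM, with an expected range of 11000 nM to 62000 nM.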

Compound 4, half-maximal cytotoxic concentration: 101000 nM
Estimate against measurement, compound 4: 3.9-fold (0.59 log units) below; measured number above the stated range.
By their numbers in this assay, from the lowest: compounds 1 and 3 (each within the scatter of the next); then compounds 2 and 4 (each within the scatter of the next).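

In this assay, the group on the saturated chain carbon proves able to move the number: 2-chloropyridin-3-yl in place of 4-(dimethylamino)phenyl gives a step beyond the scatter (a 4.1-fold higher number from compound 3 to compound 4 (0.62 log units; beyond the scatter)), whereas the earlier exchange on that carbon stayed within it. The same group in place of cyclopentyl also gives a step beyond the scatter (a 4.7-fold higher number from compound 1 to compound 4 (0.67 log units; beyond the scatter)), while the step from the cyclohexyl analogue stays within the scatter (a 1.5-fold higher number from compound 2 to compound 4 (0.17 log units; within the scatter)), so compound 2 and compound 4 cannot be told apart here. No measurement shown accounts for the change.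

The compounds shown leave open whether the ring nitrogen or the chlorine of the 2-chloropyridin-3-yl group goes with the higher number, since neither a pyridin-3-yl group without chlorine nor a chlorophenyl group stands among them.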